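The source may report more compounds than this note shows. Statements on the series, on what has been measured and on what is new or still open speak of the compounds shown alone.

Four compounds are compared here, all built on one shared core that carries two exchangeable groups. Compound 1 `COc1ccc(S(C)(=O)=O)c(NCC2=NCCN2)c1` was tested in a functional assay for agonist activity at Alpha-1A adrenergic receptor (Homo sapiens) (a higher number here means a larger maximal response, a lower number a smaller maximal response), and gives 102%. Compound 2 `COc1ccc(SC)c(NCC2=NCCN2)c1` differs from compound 1 by methylsulfanyl in place of methylsulfonyl on an aromatic carbon; in this assay compound 2 gives 101%, so the change made the step of a number 1 percentage points lower from compound 1 to compound 2 (within the scatter). Compound 3 `CS(=O)(=O)c1ccc(Cl)cc1NCC1=NCCN1` has a different core from compound 1, set apart by chloro in place of methoxy on an aromatic carbon; in this assay compound 3 gives 91%, which is the step of a number 11 percentage points lower from compound 1 to compound 3 (beyond the scatter). Compound 4 `CSc1ccc(Cl)cc1NCC1=NCCN1` has not yet been measured. It differs from compound 3 by methylsulfanyl in place of methylsulfonyl on an aromatic carbon. Going by the values given here, this is the same kind of change as the one from compound 1 to compound 2, not the same one: around the place, the group stands para to a methoxy group in the earlier pair but para to a chloro group here. Beside the earlier step of a number 1 percentage points lower from compound 1 to compound 2 (within the scatter), the step expected from this change is a number 1 percentage points lower from compound 3 to compound 4 (within the scatter), resting on that earlier step alone. For compound 4 in this assay the estimate is 90%, expected to lie between 78% and 102%.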

Compound 4, largest response reached (reported as maximum), in percent of the reference or control that the assay uses: 82%
Compound 4: middle estimate off by 8 percentage points, on the high side; the measured number falls inside the stated range.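

In this assay, putting methylsulfanyl in place of methylsulfonyl on the chloro-bearing core gives a number 9 percentage points lower from compound 3 to compound 4 (within the scatter), and this step agrees with the one seen on the methoxy-bearing core: the same change on two cores in this assay, a number 1 percentage points lower (within the scatter) from compound 1 to compound 2 and a number 9 percentage points lower (within the scatter) from compound 3 to compound 4, 8 percentage points apart, within the scatter of two such steps Putting chloro in place of methoxy, now with methylsulfanyl on the ring, gives a number 19 percentage points lower from compound 2 to compound 4 (beyond the scatter), and this step also agrees with its earlier counterpart, even though each of these two steps lies beyond the scatter: the same change on two cores in this assay, a number 11 percentage points lower (beyond the scatter) from compound 1 to compound 3 and a number 19 percentage points lower (beyond the scatter) from compound 2 to compound 4, 8 percentage points apart, within the scatter of two such steps So each change carried over from one core to the other within the limits of these measurements, but this rests on just two pairs per change and does not show that either change would behave the same way on any other core, nor does it explain why the steps agree.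

The compounds shown leave open whether a longer chain on the sulfur, or an amine or a carboxylic acid in place of the chloro or methoxy group, would fit the same picture. As far as these compounds go, only the largest response is reported, so how much of each compound is needed to reach it also remains open.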